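Working notes: phenyl for hydrogen at an aromatic nitrogen chain

The source may report more compounds than this note shows. Statements on the series, on what has been measured and on what is new or still open speak of the compounds shown alone.

Measured so far in a functional assay on aorta (Rattus norvegicus); a lower number here means a stronger inhibitor, a higher number a weaker inhibitor:
compound 1, `O=c1ccc(CCOCc2ccccc2)nn1Cc1ccccc1`, gives 32300 nM.
compound 2, `Cn1nc(CCOCc2ccccc2)ccc1=O`, gives only a limit of the assay, > 100000 nM.
compound 3, `Cn1nc(CO[Si](c2ccccc2)(c2ccccc2)C(C)(C)C)ccc1=O`, gives 58400 nM.

Compound 2 and compound 1 differ in one place: phenyl in place of hydrogen on a saturated chain carbon bound to an aromatic nitrogen. In this assay the step is an at least 3.0-fold lower number from compound 2 to compound 1 (0.49 log units; beyond the scatter). The value of compound 2 is a limit, (the limit of > 100000 nM in this assay, at which 1 of the 3 values shown sits), so the step is bounded on one side only.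

Compound 3 and compound 1 lie within the usual scatter of each other in this assay, so no order between them is read. How the core of compound 3 differs from the core of compound 2 is not broken down here.

Compound 4, `CC(C)(C)[Si](OCc1ccc(=O)n(Cc2ccccc2)n1)(c1ccccc1)c1ccccc1`, is not yet measured. It relates to compound 3 by phenyl in place of hydrogen on a saturated chain carbon bound to an aromatic nitrogen, the same change that carries compound 2 to compound 1, at the same place. The step from compound 3 to compound 4 in this assay is expected to be of a similar size, a 3.9-fold lower number from compound 3 to compound 4 (0.59 log units; beyond the scatter), resting on the measured step of an at least 3.0-fold lower number from compound 2 to compound 1 (0.49 log units; beyond the scatter) and on the value of compound 3, 58400 nM. For compound 4 the expected value in this assay is 15000 nM, estimated to fall between 5000 nM and 45000 nM.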

Compound 4, half-maximal inhibitory concentration: > 100000 nM
Compound 4 was reported as a limit; the forecaster's own chance of this, stated with the estimate: 5%; middle value at least 6.6-fold (0.82 log units) from the limit.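

In this assay compound 4 gives > 100000 nM, which is a limit of the assay and not a number. The step of an at least 1.7-fold higher number from compound 3 to compound 4 (0.23 log units; that floor lies within the scatter) does not run the same way as the earlier one, so the change from methyl to benzyl, at the same place, cannot be carried as a fixed increment from the core of compound 2 to the core of compound 3: the same change on two cores in this assay, an at least 3.0-fold lower number (0.49 log units; beyond the scatter) from compound 2 to compound 1 and an at least 1.7-fold higher number (0.23 log units; that floor lies within the scatter) from compound 3 to compound 4, at least 5.3-fold (0.72 log units) apart, beyond the scatter of two such steps. This shows only that the outcome of the change depends on the core within this pair of pairs; the size of neither step is known, each being bounded on one side only, and no cause for the gap can be read from these data: the limit of > 100000 nM in this assay, at which 2 of the 4 values shown sit.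

The compounds shown leave open which part of the side chain of compound 3 sets the outcome of the change, and whether the loss in compound 4 would persist with a smaller group such as ethyl on the same chain carbon. Also open, on these data alone, is whether a side chain ending in an amine or a carboxylic acid, in place of those on compound 1 and compound 3, would follow compound 1 or compound 4 when methyl gives way to benzyl.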